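The compounds below may be only part of what the source reports. "The series", "measured", "known", "first", "only" and "open" are said of these compounds alone.

In a functional assay on MCF7 cells (Homo sapiens) for antiproliferative activity, read by CellTiter-Glo, with a stated time of 5 days (on this read-out higher numbers stand for weaker inhibition and lower numbers for stronger inhibition), the measured compounds read:

compound 1 `O=C(O)/C=C/c1ccc(/C(=C(\c2ccc(F)cc2Cl)C2CCC2)c2ccc3scnc3c2)cc1` gives 3 nM
compound 2 `O=C(O)/C=C/c1ccc(/C(=C(\c2ccc(F)cc2Cl)C2CCC2)c2ccc(-c3cncs3)cc2)cc1` gives 4.2 nM
compound 3 `O=C(O)/C=C/c1ccc(/C(=C(\c2ccccc2)C2CCC2)c2ccc(-c3cn[nH]c3)cc2)cc1` gives 11 nM

Compound 3 has the highest number of the three, 11 nM, so it is the weakest inhibitor here. Compound 2 lies nearest to it and compound 1 furthest, and both gaps go beyond the usual scatter.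

Compound 4 `O=C(O)/C=C/c1ccc(/C(=C(\c2ccc(F)cc2Cl)C2CCC2)c2ccc(-c3cn[nH]c3)cc2)cc1` is made from compound 3 by one change: 2-chloro-4-fluorophenyl in place of phenyl on a double-bonded chain carbon bound to a double-bonded chain carbon and a saturated ring carbon. In words, 2-chloro-4-fluorophenyl stands in place of phenyl on a double-bonded chain carbon bound to a double-bonded chain carbon and a saturated ring carbon.

Going by the values given here, no measured step makes this swap on its own. Among the compounds with values here, the single step available, a 1.4-fold higher number from compound 1 to compound 2 (0.15 log units; within the scatter), lies within the scatter and concerns a different place in the molecule. Within the data shown here, it suggests only that values stay close among compounds carrying 2-chloro-4-fluorophenyl. Compound 1 at 3 nM and compound 2 at 4.2 nM both carry that group, but they also differ from compound 3 elsewhere, so this evidence is indirect.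

A drop to a lower number in this assay is therefore expected, modestly beyond the scatter. The expected change is a 2.4-fold lower number from compound 3 to compound 4 (0.39 log units; beyond the scatter). For compound 4 the estimated value is 4.5 nM, with an expected range of 1.8 nM to 11 nM.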

Compound 4, half-maximal inhibitory concentration: 2.9 nM
The estimate for compound 4 lay 1.6-fold (0.19 log units) above the measured number, and the stated range covers the measured number.
By their numbers in this assay, from the lowest: compounds 4, 1 and 2 (each within the scatter of the next); then compound 3.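

In this assay, the swap from phenyl to 2-chloro-4-fluorophenyl on a double-bonded chain carbon bound to a double-bonded chain carbon and a saturated ring carbon gives a 3.8-fold lower number from compound 3 to compound 4 (0.58 log units; beyond the scatter). Going by these compounds alone, this is the first direct reading of that change, with everything else in the molecule held the same, and it shows that the group alone moves the number beyond the scatter. With 2-chloro-4-fluorophenyl in place, the other arm of the molecule can vary with little effect: 1H-pyrazol-4-yl in place of 1,3-thiazol-5-yl gives a 1.4-fold lower number from compound 2 to compound 4 (0.16 log units; within the scatter), and 4-(1H-pyrazol-4-yl)phenyl in place of 1,3-benzothiazol-5-yl gives a 1.0-fold lower number from compound 1 to compound 4 (0.01 log units; within the scatter), so compounds 1, 2 and 4 cannot be put in any order.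

No measurement here accounts for the effect of the swap. The compounds shown also leave open whether the chlorine or the fluorine alone would give the same step, and how a ring carrying a methoxy group or an amine would read at this position.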